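This account rests on a few compounds, and the source may have more. Where it says the series, first, only, none or still open, it means among the compounds named here.

In a functional assay on A549 cells (Homo sapiens) for inhibition, read by MTT assay, with a stated time of 48 h (a higher number here means a weaker inhibitor, a lower number a stronger inhibitor), compound 1 `COc1ccc2c(=O)c(/C=C/C(=O)Nc3ccc(C)cc3)coc2c1` gives 17500 nM. Compound 2 `COc1ccc2c(=O)c(/C=C/C(=O)Nc3cc(C)ccc3C)coc2c1` gives 15500 nM in this assay and so stands at the lower of the two numbers, though the step of a 1.1-fold lower number from compound 1 to compound 2 (0.05 log units; within the scatter) lies within the scatter, so the two are not distinguished. Among the compounds with values here, compound 3 `Cc1ccccc1NC(=O)/C=C/c1coc2cc(O)ccc2c1=O` returns only a limit in this assay, > 100000 nM, and this limit, (the limit of > 100000 nM in this assay, at which 1 of the 3 values shown sits), is the one such value among the three.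

Compound 4 `COc1ccc2c(=O)c(/C=C/C(=O)NCc3ccc(C)cc3)coc2c1` differs from compound 2 in one place: 4-methylbenzyl in place of 2,5-dimethylphenyl on an amide-type nitrogen. Within the data shown here, the only measured step at the amide-type nitrogen, a 1.1-fold lower number from compound 1 to compound 2 (0.05 log units; within the scatter), exchanged one aromatic group for another and stayed within the scatter; no measured step exchanges an aromatic group for a benzyl group, so this change has no direct precedent here. Compound 4 is therefore expected to stay close to compound 2, with the step of a 1.3-fold higher number from compound 2 to compound 4 (0.11 log units; within the scatter) not beyond the scatter. Compound 4 is estimated at 20000 nM in this assay, with a range from 7000 nM to 60000 nM.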

Compound 4, half-maximal inhibitory concentration: > 100000 nM
Compound 4: only a limit was reported (the forecaster's own chance of this, stated with the estimate: 15%); at least 5.0-fold (0.69 log units) between middle value and limit.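

In this assay, the amide-type nitrogen proves not to tolerate every change: the earlier exchange of one aromatic group for another stayed within the scatter (a 1.1-fold lower number from compound 1 to compound 2 (0.05 log units; within the scatter)), whereas 4-methylbenzyl in place of 2,5-dimethylphenyl gives an at least 6.4-fold higher number from compound 2 to compound 4 (0.80 log units; beyond the scatter). The same holds against the other aromatic group, with 4-methylbenzyl in place of 4-methylphenyl giving an at least 5.7-fold higher number from compound 1 to compound 4 (0.75 log units; beyond the scatter), so the result does not rest on a single reference compound. The value of compound 4 is a limit of the assay, which leaves the full size of both steps unknown, and it is the same limit as that of compound 3: the limit of > 100000 nM in this assay, at which 2 of the 4 values shown sit.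

The compounds shown leave open whether a longer chain on this nitrogen, such as 2-phenylethyl, would sit at the same limit. They also leave open whether an amine on the benzyl ring would bring the number back towards that of compound 2.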